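This account rests on a few compounds, and the source may have more. Where it says the series, first, only, none or still open, it means among the compounds named here.

Measured in an ADME assay on the whole organism for pharmacokinetics, with Rattus norvegicus as the target; on this read-out lower numbers stand for lower oral bioavailability and higher numbers for higher oral bioavailability
compound 1 (`O=S(=O)(c1ccc(O)c2ncccc12)C1CCCC1`) gives 24%
compound 2 (`O=S(=O)(c1ccc(C(F)(F)F)cc1)c1cc(F)c(O)c2ncccc12`) gives 66%
compound 3 (`O=S(=O)(c1ccc(F)cc1)c1cc(Cl)c(O)c2ncccc12`) gives 23%

Compound 3 at 23% lies within the scatter of compound 1 and beyond the scatter below compound 2 . Compound 4 (`O=S(=O)(c1ccc(F)cc1)c1cc(F)c(O)c2ncccc12`) carries fluoro in place of chloro on an aromatic carbon, ortho to a hydroxy group (fluoro in place of chloro on an aromatic carbon). Among the measured compounds shown here, no measured pair isolates this change. Compound 2 has fluoro at that place and gives 66%, but it also differs from compound 3 in a second place, so it offers only a weak guide. A modest upward step is expected in this assay, estimated as a number 12 percentage points higher from compound 3 to compound 4 (beyond the scatter), close to the edge of the scatter. For compound 4 the estimated value is 35%, with an expected range of 15% to 60%.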

Compound 4, oral bioavailability: 100%
Estimate against measurement, compound 4: 65 percentage points below, outside the stated range (above it).
By their numbers in this assay, from the lowest: compounds 3 and 1 (each within the scatter of the next); then compound 2; then compound 4.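

In this assay, among the compounds shown here, fluoro in place of chloro on an aromatic carbon, ortho to a hydroxy group, gives a number 77 percentage points higher from compound 3 to compound 4 (beyond the scatter), the first reading of this change alone and a large one. The second single change, fluoro in place of trifluoromethyl on an aromatic carbon, gives a number 34 percentage points higher from compound 2 to compound 4 (beyond the scatter), so this read-out also responds strongly to the group at that other place. Nothing available accounts for either step.

Going by these compounds, whether the chloro-to-fluoro step holds alongside trifluoromethyl remains open. So does the outcome with methoxy or an amine ortho to the hydroxy group.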